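This account rests on a few compounds, and the source may have more. Where it says the series, first, only, none or still open, it means among the compounds named here.

Measured compounds:
Compound 1, `CCOc1ccc(/C=N/NC(N)=S)c2ccccc12` — > 200000 nM
Compound 2, `CCCCOc1c(/C=N/NC(N)=S)ccc2ccccc12` — > 200000 nM

In a toxicity assay on THP-1 cells (Homo sapiens) for cytotoxicity, read by MTT assay, with a stated time of 72 h (on this read-out higher numbers stand for an effect only at larger amounts of compound and lower numbers for an effect already at smaller amounts), compound 1 gives > 200000 nM, which is a limit of the assay rather than a number. Compound 2 gives > 200000 nM in this assay, again a limit. Both values sit at the limit of > 200000 nM in this assay, at which 2 of the 2 values shown sit, so compound 2 stands nowhere above or below compound 1; the two are simply indistinguishable at the edge of the tested range.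

Compound 3, `NC(=S)N/N=C/c1ccc2ccccc2c1OCc1ccccc1`, has not yet been measured in this assay. It differs from compound 2 in one place: phenyl in place of propyl on a saturated chain carbon bound to an oxygen on an aromatic ring. Among the compounds with values here, no step between measured compounds exists that would suggest a direction for this change, and compound 2 itself offers only a limit. The step from compound 2 to compound 3 is therefore expected to be none beyond the scatter, that is a number no higher from compound 2 to compound 3 (the limit leaves the size open). For compound 3 in this assay the estimate is 200000 nM, with a range from 60000 nM to 600000 nM, and most likely the assay reports only a limit again.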

Compound 3, half-maximal effective concentration: 28000 nM
Beside the measured number, compound 3's estimate is 7.1-fold (0.85 log units) above it, outside the stated range (below it).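

The place on a saturated chain carbon bound to an oxygen on an aromatic ring is not silent in this assay: phenyl in place of propyl, that is benzyloxy for butoxy, gives an at least 7.1-fold lower number from compound 2 to compound 3 (0.85 log units; beyond the scatter). Within the data shown here, this single change brings an effect into the tested range, with compound 3 at 28000 nM, where the earlier compounds offered no number to compare. Compound 2 gives > 200000 nM, which is a limit of the assay, so the step has a lower bound but no known full size: the limit of > 200000 nM in this assay, at which 2 of the 3 values shown sit.

The compounds shown cannot tell whether the aromatic ring or simply the greater number of carbons accounts for the step, which a cyclohexyl or a longer chain in the same place would separate. They also leave open how an amine or a carboxylic acid on the phenyl would move the number.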